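From 2-fluorobenzyl to 3-fluorobenzyl

A few compounds are considered here, and "the series" means these few. Any claim that something is new, unique, unknown or untested is made for them only; others in the source may bear on it.

In a functional assay on K562 cells (Homo sapiens) for cytotoxicity, read by MTT assay, with a stated time of 48 h (on this read-out higher numbers stand for weaker inhibition and lower numbers for stronger inhibition), compound 1 `Cc1ccccc1CN1CCN(C(=O)CN[C@H]2CCN(S(=O)(=O)Cc3ccccc3)C2)CC1` gives 10200 nM, compound 2 `O=C(CN[C@H]1CCN(S(=O)(=O)Cc2ccccc2)C1)N1CCN(Cc2ccc(Cl)cc2)CC1` gives 9200 nM and compound 3 `O=C(CN[C@H]1CCN(S(=O)(=O)Cc2ccccc2)C1)N1CCN(Cc2ccccc2F)CC1` gives 12600 nM. Compound 3 therefore stands level with the other two, its steps to both lying within the scatter. Compound 4 `O=C(CN[C@H]1CCN(S(=O)(=O)Cc2ccccc2)C1)N1CCN(Cc2cccc(F)c2)CC1` carries 3-fluorophenyl in place of 2-fluorophenyl on a saturated chain carbon bound to an amine nitrogen in a ring. Within the data shown here, no measured pair shows this exact change. The nearest evidence comes from the changes to the same aromatic group: a 1.1-fold lower number from compound 1 to compound 2 (0.04 log units; within the scatter), a 1.2-fold higher number from compound 1 to compound 3 (0.09 log units; within the scatter) and a 1.4-fold higher number from compound 2 to compound 3 (0.14 log units; within the scatter). All three stayed within the scatter, so no step beyond the scatter is expected in this assay. The estimated change is a 1.1-fold lower number from compound 3 to compound 4 (0.06 log units; within the scatter). Compound 4 is expected at 11000 nM, with an estimated range of 6500 nM to 18000 nM.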

Compound 4, half-maximal inhibitory concentration: 13200 nM
For compound 4 the middle estimate is 1.2-fold (0.08 log units) below the measured one; the measured number falls inside the stated range.
By their numbers in this assay, from the lowest: compounds 2, 1, 3 and 4 (each within the scatter of the next).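

In this assay the move from 2-fluorobenzyl to 3-fluorobenzyl gives a 1.0-fold higher number from compound 3 to compound 4 (0.02 log units; within the scatter) and so shows that shifting the fluorine within this group, rather than exchanging the group's substituent, also leaves the number within the scatter. The new fluorinated group also stays level with the two other substituted groups, with a 1.4-fold higher number from compound 2 to compound 4 (0.16 log units; within the scatter) and a 1.3-fold higher number from compound 1 to compound 4 (0.11 log units; within the scatter) in this series. All four compounds therefore remain level at this position on a saturated chain carbon bound to an amine nitrogen in a ring.

Going by these compounds, whether an amine or a carboxylic acid on the phenyl group would produce a step beyond the scatter stays open. Nothing shown here bears on why these numbers stay so close.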